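Adding a Second Methoxy Group to Two Weak Growth Inhibitors

A few compounds are considered here, and "the series" means these few. Any claim that something is new, unique, unknown or untested is made for them only; others in the source may bear on it.

Measured compounds:
compound 1, `COc1ccc(/C=C/c2cc(=O)cco2)cc1` — 310 uM
compound 2, `COc1ccc(/C=C/c2cc(=O)cco2)cc1OC` — 408 uM
compound 3, `COc1ccc(/C=C/C2CC=CC(=O)N2)cc1` — 842 uM

All three numbers come from a functional assay on NCI/ADR cells (Homo sapiens) for inhibition, read by sulforhodamine B assay, with a stated time of 48 h; a higher number here means a weaker inhibitor of growth, a lower number a stronger inhibitor of growth. Compound 1 and compound 2 share one core, and compound 3 has a different one; how the two cores differ is not broken down here. Compound 3 gives the highest number of the three, and its gaps to compound 2 and to compound 1 are both beyond the usual scatter of repeated measurements.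

Compound 2 is made from compound 1 by one change: methoxy in place of hydrogen on an aromatic carbon. That change gave a 1.3-fold higher number from compound 1 to compound 2 (0.12 log units; within the scatter), a step too small to stand out from the scatter.

Compound 4, `COc1ccc(/C=C/C2CC=CC(=O)N2)cc1OC`, is not yet measured. Among the measured compounds shown here, it is made from compound 3 by methoxy in place of hydrogen on an aromatic carbon, which is the same change as the one from compound 1 to compound 2, made at the same place on the same kind of ring. For the measured compounds named here, the expectation for compound 4 therefore rests on the one measured example: because a 1.3-fold higher number from compound 1 to compound 2 (0.12 log units; within the scatter) barely moved the number, the step in this assay is expected to be about as small, namely a 1.3-fold higher number from compound 3 to compound 4 (0.12 log units; within the scatter). On that basis compound 4 is estimated to give 1100 uM in this assay, with a likely range from 600 uM to 2000 uM. Since compound 3 already sits high, there is some chance that this assay reports only a limit for compound 4 rather than a number.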

Compound 4, concentration for growth inhibition (reported as GI): > 964 uM
Compound 4: no number, only a limit; the forecaster's own chance of this, stated with the estimate: 25%; the middle value is on the limit's open side.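

In this assay compound 4 gives > 964 uM, which is a limit of the assay and not a number. Placing methoxy instead of hydrogen on the aromatic carbon ortho to a methoxy group gives an at least 1.1-fold higher number from compound 3 to compound 4 (0.05 log units; that floor lies within the scatter), and this figure is only a floor for the step, not its size. The result fits a small step on both cores, yet it also allows a much larger step on the core of compound 3, so it cannot confirm that the change carries over from one core to the other with the same size: the same change on two cores in this assay, a 1.3-fold higher number (0.12 log units; within the scatter) from compound 1 to compound 2 and an at least 1.1-fold higher number (0.05 log units; that floor lies within the scatter) from compound 3 to compound 4; the limit leaves it open whether they differ

The compounds shown leave open what other groups would do at this same aromatic carbon, such as a hydroxyl, a fluorine or an amine, and whether any of them would give a lower number on either core. The true value of compound 4 also remains open, and the comparison between the two cores can go no further until a number replaces the limit: the limit of > 964 uM in this assay, at which 1 of the 4 values shown sits.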